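From Ethyl to Tert-Butyl: An Expected Small Shift

A few compounds are considered here, and "the series" means these few. Any claim that something is new, unique, unknown or untested is made for them only; others in the source may bear on it.

In a functional assay on M21 cells (Homo sapiens) for antiproliferative activity, read by sulforhodamine B assay, with a stated time of 48 h (a higher number here means a weaker inhibitor, a lower number a stronger inhibitor), compound 1 `O=C1NCCN1c1ccc(S(=O)(=O)Nc2ccc(C3CCCCC3)cc2)cc1` gives only a limit, > 1000 nM, and not a number. Within the data shown here, compound 2 `CCc1ccc(NS(=O)(=O)c2ccc(N3CCNC3=O)cc2)cc1` gives 480 nM, so it holds the only exact value available so far. Compound 3 `CC(C)(C)c1ccc(NS(=O)(=O)c2ccc(N3CCNC3=O)cc2)cc1` keeps the rest of compound 2 and changes one group, with tert-butyl in place of ethyl on an aromatic carbon, para to a large group: tert-butyl in place of ethyl on an aromatic carbon.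

Just one measured step bears on this change: an at least 2.0-fold lower number from compound 1 to compound 2 (0.31 log units; beyond the scatter), where ethyl replaced cyclohexyl on an aromatic carbon. On these data alone, one end of that step is the limit of > 1000 nM in this assay, at which 1 of the 2 values shown sits, so its full size remains open. It does suggest that the group at this place can matter, and that the ethyl compound has the lower number of the pair. Going by an at least 2.0-fold lower number from compound 1 to compound 2 (0.31 log units; beyond the scatter), a modest rise in the number in this assay is expected on moving to tert-butyl, though a change no larger than the scatter would be no surprise. The expected move is a 1.4-fold higher number from compound 2 to compound 3 (0.13 log units; within the scatter). For compound 3 the estimated value is 650 nM, within an expected range of 250 nM to 1700 nM.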

Compound 3, half-maximal inhibitory concentration: > 1000 nM
Compound 3: a limit, no number; the forecaster's own chance of this, stated with the estimate: 25%; at least 1.5-fold (0.18 log units) between middle value and limit.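

Moving from ethyl to tert-butyl gives an at least 2.0-fold higher number from compound 2 to compound 3 (0.31 log units; beyond the scatter) in this assay, so this position does not take any carbon group equally well, even when the change adds only a small branched group and no ring. The earlier step could have been read as a matter of the ring in cyclohexyl, but tert-butyl has no ring and compound 3 also ends at a limit, so among the three compounds shown, only ethyl gives an exact value at this place. The full size of the new step cannot be read, and neither can any step between compound 1 and compound 3, because these compounds carry limits and not numbers: the limit of > 1000 nM in this assay, at which 2 of the 3 values shown sit.

On these data alone, what remains open is whether a group smaller than ethyl, such as methyl or a single hydrogen, would give a lower number than compound 2 or a higher one. As far as these compounds go, it is also open how a group containing atoms other than carbon, such as an amine or a methoxy group, would behave at this same place on the ring.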